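The source may report more compounds than this note shows. Statements on the series, on what has been measured and on what is new or still open speak of the compounds shown alone.

Measured so far:
- compound 1 `CN1CCCc2ccc(NC(=O)c3ccc(-c4ccsc4)cc3)cc21`: 7.8
- compound 2 `CN1CCCc2ccc(NC(=O)c3ccc(-c4cncnc4)cc3)cc21`: 6.9

Both numbers come from a functional assay for antagonist activity at transient receptor potential cation channel subfamily V member 1 (Homo sapiens), read by FLIPR and calcium flux; on this read-out lower numbers stand for lower potency and higher numbers for higher potency (the scale is a negative logarithm). Compound 1 gives 7.8 and compound 2 gives 6.9, so compound 2 stands lowest of the two, the gap to compound 1 being beyond the scatter: a number 0.90 log units lower from compound 1 to compound 2 (beyond the scatter) for pyrimidin-5-yl in place of thiophen-3-yl on an aromatic carbon.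

Compound 3 `CN1CCCc2ccc(NC(=O)c3ccc(-c4cnccn4)cc3)cc21` has not been measured. It differs from compound 2 as follows: pyrazin-2-yl in place of pyrimidin-5-yl on an aromatic carbon.

Among the compounds with values here, the only measured step, a number 0.90 log units lower from compound 1 to compound 2 (beyond the scatter), exchanges a five-membered ring for a six-membered one and does not bear directly on a rearrangement within a six-membered aromatic ring carrying two nitrogen atoms. Within the data shown here, no measured pair shows a pyrazin-2-yl group. In the absence of a bearing step, compound 3 is expected to stay close to compound 2, with a step of no change at the digits printed from compound 2 to compound 3 (within the scatter) in this assay, that is none beyond the scatter. Among the measured compounds shown here, the estimate for compound 3 in this assay is 6.9, with a range from 6.3 to 7.5, wide because only one step is known.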

Compound 3, negative logarithm of the antagonist equilibrium constant: 7.1
For compound 3 the middle estimate is 0.20 log units below the measured one, within the range that was stated.
By their numbers in this assay, from the lowest: compounds 2 and 3 (each within the scatter of the next); then compound 1.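

In this assay, the exchange of pyrimidin-5-yl for pyrazin-2-yl, on an aromatic carbon para to a large group, leaves the heavy-atom make-up of the group unchanged and reads a number 0.20 log units higher from compound 2 to compound 3 (within the scatter), so these two arrangements of the ring nitrogen atoms cannot be told apart at this position. The second six-membered ring with two hetero atoms also stays clear of the thiophen-3-yl compound, with the exchange reading a number 0.70 log units lower from compound 1 to compound 3 (beyond the scatter), which shows that the gap to compound 1 is not confined to the pyrimidin-5-yl group. No supporting measurement bears on why the thiophen-3-yl compound stands apart from these two groups.

Thiophen-3-yl differs from both six-membered groups in ring size and in its hetero atom, and the compounds shown do not separate these features. Phenyl and pyridin-3-yl groups at the same position would help to separate them, while a pyrimidin-2-yl group or a thiophen-2-yl group would test how far the position of the hetero atoms matters within each ring size.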